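The source may hold more compounds than are shown below. What is called first, only, known or untested is meant among the compounds shown, and "the series" means these compounds.

Compound 1 `O=C1C(c2ccccc2)CC(c2ccccc2)C(=O)N1c1ccccc1`: 43.7 mg/kg
Compound 2 `O=C1C(c2ccccc2)CC(c2ccccc2)C(=O)N1Cc1ccccc1`: 14 mg/kg

Of the compounds shown here, two have so far been measured in a functional assay on the whole organism (strain Swiss albino) with Mus musculus as the target, in the maximal electroshock model, with a stated time of 2 h; on this read-out higher numbers stand for an effect only at larger amounts of compound and lower numbers for an effect already at smaller amounts. Compound 1 gives 43.7 mg/kg, the higher of the two numbers. For the measured compounds named here, the only measured step is a 3.1-fold lower number from compound 1 to compound 2 (0.49 log units; beyond the scatter), a modest change that nonetheless lies beyond the scatter; it exchanges benzyl for phenyl on the amide-type ring nitrogen of the shared core.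

Compound 3 `Cc1ccccc1N1C(=O)C(c2ccccc2)CC(c2ccccc2)C1=O` has not yet been measured. It differs from compound 1 by methyl in place of hydrogen on an aromatic carbon. The measured step touches the same nitrogen substituent, but in a different way: it replaces the whole phenyl by benzyl, whereas compound 3 keeps the phenyl and adds a methyl to it. Going by the values given here, no measured pair shows what a methyl on that aromatic ring does, so the expectation rests on the general size of changes seen here rather than on a direct precedent. The expected step for compound 3 is a 1.1-fold lower number from compound 1 to compound 3 (0.04 log units; within the scatter) in this assay, that is, no change clearly beyond the scatter in either direction. Compound 3 is therefore estimated at 40 mg/kg, within a range from 18 mg/kg to 90 mg/kg.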

Compound 3, dose for half-maximal effect: 21.5 mg/kg
For compound 3 the middle estimate is 1.9-fold (0.27 log units) above the measured one; low and high end bracket the measured number.
By their numbers in this assay, from the lowest: compounds 2 and 3 (each within the scatter of the next); then compound 1.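

In this assay, adding a single methyl to the nitrogen-bound phenyl, on an aromatic carbon ortho to a large group, gives a 2.0-fold lower number from compound 1 to compound 3 (0.31 log units; beyond the scatter). This shows that the phenyl of compound 1 responds to a change of one heavy atom, whereas the earlier step showed only the exchange of the whole group for benzyl. The comparison with the benzyl compound gives a 1.5-fold higher number from compound 2 to compound 3 (0.19 log units; within the scatter), so 2-methylphenyl and benzyl on this nitrogen give numbers that cannot be told apart in this read-out, and nothing at hand accounts for the effect of the methyl.

The compounds shown leave open whether the result is specific to methyl or would carry over to an ethyl, a methoxy, a chlorine or an amine at the same place on the ring. They also leave open what the same methyl would do on the benzyl ring of compound 2, and how the number would respond to changes in the two phenyl groups carried by the shared core.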